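The compounds below may be only part of what the source reports. "The series", "measured", "known", "first", "only" and "open" are said of these compounds alone.

Measured compounds:
- compound 1, `CCn1c(C(=O)N[C@@H](C)CO)ccc1C(CC)(CC)c1ccc(OCS(=O)(=O)c2ccccc2)c(C)c1`: 9520 nM
- compound 2, `CCn1c(C(=O)N[C@@H](CO)CCCO)ccc1C(CC)(CC)c1ccc(OCS(=O)(=O)c2ccccc2)c(C)c1`: 13400 nM

In a functional assay on PC-3 cells (Homo sapiens) for antiproliferative activity, read by MTT assay, with a stated time of 24 h (on this read-out higher numbers stand for weaker inhibition and lower numbers for stronger inhibition), the numbers of compound 2 and compound 1 lie within the scatter of each other, so neither stands apart. Compound 3, `CCn1c(C(=O)N[C@H](CC(=O)O)C(=O)O)ccc1C(CC)(CC)c1ccc(OCS(=O)(=O)c2ccccc2)c(C)c1`, differs from compound 2 by a group of 8 heavy atoms (4 carbon, 4 oxygen; no ring) in place of a group of 7 heavy atoms (5 carbon, 2 oxygen; no ring), on an amide-type nitrogen. Within the data shown here, the only measured step at this amide-type nitrogen, a 1.4-fold higher number from compound 1 to compound 2 (0.15 log units; within the scatter), swapped one hydroxy-bearing chain for another and changed little; it does not cover a 1,2-dicarboxyethyl group, so the expectation rests on weak ground. Compound 3 is expected to give about 15000 nM, within 5000 nM to 50000 nM, a step of a 1.1-fold higher number from compound 2 to compound 3 (0.05 log units; within the scatter) that is expected to stay within the scatter.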

Compound 3, half-maximal inhibitory concentration: > 50000 nM
Compound 3: a limit, no number (the forecaster's own chance of this, stated with the estimate: 25%); at least 3.3-fold (0.52 log units) between middle value and limit.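

Among these compounds, the earlier change on this amide-type nitrogen stayed within the scatter, but 1,2-dicarboxyethyl is the first group here to move the result beyond it in this assay, with an at least 3.7-fold higher number from compound 2 to compound 3 (0.57 log units; beyond the scatter) and an at least 5.2-fold higher number from compound 1 to compound 3 (0.72 log units; beyond the scatter). The group on this nitrogen can therefore matter, and here the inhibition is weaker. The result for compound 3 is a limit, not a number: the limit of > 50000 nM in this assay, at which 1 of the 3 values shown sits.

As far as these compounds go, how much weaker compound 3 is remains open. It is also unclear whether a carboxymethyl group, with one carboxylic acid, or a chain ending in an amine would behave like 1,2-dicarboxyethyl or like the hydroxy-bearing chains.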